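This account rests on a few compounds, and the source may have more. Where it says the series, first, only, none or still open, it means among the compounds named here.

Two compounds of the series carry numbers in a functional assay on MCF7 cells (Homo sapiens) for cytotoxicity, read by sulforhodamine B assay, with a stated time of 48 h; a higher number here means a weaker inhibitor of growth, a lower number a stronger inhibitor of growth. Compound 1 `CCN(CC)CN1C(=O)/C(=N\c2nc3ccc(C)cc3s2)c2ccccc21` gives 74800 nM in this assay, and compound 2 `Cc1ccc2nc(/N=C3\C(=O)N(CN(C)C)c4ccccc43)sc2c1` gives 29200 nM. Within the data shown here, the single measured step, a 2.6-fold lower number from compound 1 to compound 2 (0.41 log units; beyond the scatter), is the only change documented so far, so compound 2 stands at the lowest of the two numbers, with compound 1 as its nearest neighbour at the higher value.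

Compound 3 `Cc1ccc2nc(/N=C3\C(=O)N(CN(C)C)c4cccc(Cl)c43)sc2c1` differs from compound 2 by chloro in place of hydrogen on an aromatic carbon; the altered carbon belongs to the ring system of the shared core, not to the chain carried by the amide-type nitrogen. Among the measured compounds shown here, no measured step touches an aromatic carbon of the core; the change between compound 1 and compound 2 concerns a different part of the molecule and offers no guide to the size or direction of a ring substitution. The expectation for compound 3 in this assay therefore rests on compound 2 alone. For compound 3 the expected step is a 1.2-fold lower number from compound 2 to compound 3 (0.07 log units; within the scatter), with a wide range around it. Compound 3 is estimated at 25000 nM, between 8000 nM and 80000 nM.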

Compound 3, concentration for 50% growth inhibition: 20700 nM
Beside the measured number, compound 3's estimate is 1.2-fold (0.08 log units) above it; measured number inside the range.
By their numbers in this assay, from the lowest: compounds 3 and 2 (each within the scatter of the next); then compound 1.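

In this assay, chloro in place of hydrogen on an aromatic carbon of the shared core gives a 1.4-fold lower number from compound 2 to compound 3 (0.15 log units; within the scatter) and so separates compound 3 from compound 2 by no more than repeated measurements would. Among these compounds, this is the first reading for a change on this ring: the carbon, ortho to a fused ring and meta to a fused ring, carries a chloro with no change in the number that can be told from the scatter, while the only step beyond the scatter remains a 2.6-fold lower number from compound 1 to compound 2 (0.41 log units; beyond the scatter) on the chain at the amide-type nitrogen. No measurement of any property bears on this result, so it stands as a number without an account behind it.

On these data alone, it remains open whether a different group on this carbon, such as methoxy, an amine or a carboxylic acid, would move the number beyond the scatter, and whether chloro on another aromatic carbon of the core would read as it does here. Also open, as far as these compounds go, is whether the chloro reads the same with diethylamino or a longer chain in place of dimethylamino.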